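Bromo for Methoxy: One Change Seen Twice

The source may report more compounds than this note shows. Statements on the series, on what has been measured and on what is new or still open speak of the compounds shown alone.

Compound 1 `COc1ccc(-c2cc3ccc(OCCCn4cc(CNC(=O)CCCCC5CCSS5)nn4)cc3oc2=O)cc1` and compound 2 `O=C(CCCCC1CCSS1)NCc1cn(CCCOc2ccc3cc(-c4ccc(Br)cc4)c(=O)oc3c2)nn1` share a core and differ by bromo in place of methoxy on an aromatic carbon. In a functional assay on PC-12 cells (Rattus norvegicus) for cytotoxicity, read by MTT assay, with stated times of 3 h and 2 h, tested at 10 uM (a lower number here means a weaker effect, a higher number a stronger effect of the compound at the concentration tested), compound 1 gives 57.6% and compound 2 gives 63.3%, so a number 5.7 percentage points higher from compound 1 to compound 2 (within the scatter). Compound 3 `COc1ccc(-c2cc3ccc(OCCCCn4cc(CNC(=O)CCCCC5CCSS5)nn4)cc3oc2=O)cc1` carries a core whose difference from that of compound 1 is not broken down here; in this assay compound 3 gives 48.6%, the lowest of the three numbers. Compound 4 `O=C(CCCCC1CCSS1)NCc1cn(CCCCOc2ccc3cc(-c4ccc(Br)cc4)c(=O)oc3c2)nn1` stands to compound 3 as compound 2 stands to compound 1, differing by bromo in place of methoxy on an aromatic carbon, the same change at the same place. Its read-out in this assay is not yet known. Because a number 5.7 percentage points higher from compound 1 to compound 2 (within the scatter) was within the scatter, the corresponding step is expected to be small, estimated as a number 5.4 percentage points higher from compound 3 to compound 4 (within the scatter). Compound 4 is therefore expected at about 54%, likely between 40% and 68%.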

Compound 4, a percentage reported as activity, at one concentration (the size of the read-out at that concentration, not a potency): 42.6%
Compound 4: middle estimate off by 11.4 percentage points, on the high side; low and high end bracket the measured number.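

In this assay, the change from 4-methoxyphenyl to 4-bromophenyl on the second core gives a number 6 percentage points lower from compound 3 to compound 4 (within the scatter). Set beside the step on the first core, this one does not differ from it beyond the scatter: the same change on two cores in this assay, a number 5.7 percentage points higher (within the scatter) from compound 1 to compound 2 and a number 6 percentage points lower (within the scatter) from compound 3 to compound 4, 11.7 percentage points apart, within the scatter of two such steps

Going by these compounds alone, on these two cores, then, the change carries over as a step that cannot be told from no step at all, but two pairs in a single assay give it no reliable direction and say nothing about other cores. The compounds shown leave open what an amine or a carboxylic acid would do at this place on the aromatic ring. They also leave open how either bromo or methoxy would fare with a longer chain.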